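A few compounds are considered here, and "the series" means these few. Any claim that something is new, unique, unknown or untested is made for them only; others in the source may bear on it.

The measured compounds are these. Compound 1, `COc1ccc(Nc2nc(-c3ccccn3)cs2)cc1`, gives 80000 nM in a physicochemical assay for solubility, in phosphate buffer, with a stated time of 2 h, at pH 7.4; on this read-out higher numbers stand for higher solubility and lower numbers for lower solubility. Compound 2, `COc1ccc(Nc2nc(-c3ccccn3)cs2)cc1OC`, gives 10000 nM in this assay. Compound 3, `Clc1ccc(Nc2nc(-c3ccccn3)cs2)nc1`, returns only a limit of the assay in this assay, namely < 10000 nM.

Compound 2 differs from compound 1 by methoxy in place of hydrogen on an aromatic carbon, and that step is an 8.0-fold lower number from compound 1 to compound 2 (0.90 log units; beyond the scatter). Compound 4, `COc1cccc(-c2csc(Nc3ccc(Cl)cn3)n2)n1`, has not yet been measured; it differs from compound 3 by methoxy in place of hydrogen on an aromatic carbon. Among the compounds with values here, this is the same kind of change as the one from compound 1 to compound 2, though the surroundings differ: in compound 2 the new group sits on a six-membered aromatic ring of carbon only, ortho to a methoxy group, while in compound 4 it sits on a six-membered aromatic ring with 1 nitrogen, next to the ring nitrogen. The difference between the cores of compound 1 and compound 3 is not broken down here. Compound 3 sits at the limit of < 10000 nM in this assay, at which 1 of the 3 values shown sits. Because the same kind of change gave an 8.0-fold lower number from compound 1 to compound 2 (0.90 log units; beyond the scatter), the step from compound 3 to compound 4 is expected to be a step that the limit leaves unreadable from compound 3 to compound 4. Compound 4 is therefore estimated at 2000 nM, between 300 nM and 10000 nM.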

Compound 4, solubility: < 10000 nM
Compound 4 ended at the assay's limit; the forecaster's own chance of this, stated with the estimate: 80%; the middle value does not contradict the limit.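

Compound 3 and compound 4 both stand at a limit of the assay, so no step can be read between them: the limit of < 10000 nM in this assay, at which 2 of the 4 values shown sit.

The compounds shown leave open whether methoxy in place of hydrogen on an aromatic carbon, on the core of compound 3, gives anything like the earlier step, an 8.0-fold lower number from compound 1 to compound 2 (0.90 log units; beyond the scatter).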